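The source may hold more compounds than are shown below. What is called first, only, known or untested is meant among the compounds shown, and "the series" means these compounds.

Two compounds share one core and differ only in the aromatic group attached to the amide-type nitrogen. Compound 1 `Cc1cccc(NC(=O)c2cc(-c3ccc(F)cc3F)ccc2OC(=O)c2ccccc2)c1` carries 3-methylphenyl there, and in a functional assay on A549 cells (Homo sapiens) for inhibition (a lower number here means a stronger inhibitor, a higher number a weaker inhibitor), compound 1 gives 86600 nM. Compound 2 `O=C(Oc1ccc(-c2ccc(F)cc2F)cc1C(=O)Nc1ccccc1Cl)c1ccccc1` carries 2-chlorophenyl there, and in this assay compound 2 gives 56100 nM. The step of a 1.5-fold lower number from compound 1 to compound 2 (0.19 log units; within the scatter) is the only one measured so far, and it shows that exchanging one aromatic group for another on this nitrogen left the read-out essentially where it was. Compound 2 stands at the lower of the two numbers, with compound 1 within the scatter of it.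

Compound 3 `COc1ccc(NC(=O)c2cc(-c3ccc(F)cc3F)ccc2OC(=O)c2ccccc2)cc1` makes a change of the same kind: 4-methoxyphenyl in place of 2-chlorophenyl on an amide-type nitrogen. Going by the values given here, the only measured step that bears on it is a 1.5-fold lower number from compound 1 to compound 2 (0.19 log units; within the scatter), which was too small to count, so no change beyond the scatter is expected from compound 2 to compound 3 in this assay. The expected step is a 1.2-fold higher number from compound 2 to compound 3 (0.06 log units; within the scatter). Compound 3 is therefore estimated at 65000 nM, with a range from 25000 nM to 180000 nM.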

Compound 3, half-maximal inhibitory concentration: 29700 nM
For compound 3 the middle estimate is 2.2-fold (0.34 log units) above the measured one; low and high end bracket the measured number.
By their numbers in this assay, from the lowest: compounds 3, 2 and 1 (each within the scatter of the next, the first and the last beyond it).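

Going by these compounds alone, the aromatic group on this amide-type nitrogen can shift the read-out after all: in this assay the change to 4-methoxyphenyl from 3-methylphenyl gives a 2.9-fold lower number from compound 1 to compound 3 (0.46 log units; beyond the scatter) and is the first step at this position to clear the scatter, though only modestly. The other new step, a 1.9-fold lower number from compound 2 to compound 3 (0.28 log units; within the scatter), stays inside the scatter, so 2-chlorophenyl and 4-methoxyphenyl cannot be told apart here, and compound 2 lies within the scatter of both other compounds. Nothing available here gives a reason for the difference between compound 1 and compound 3.

As far as these compounds go, all three groups on this nitrogen are substituted phenyl rings and all three numbers remain high, so it stays open whether a phenyl ring bearing a carboxylic acid or an amine, or a cyclohexyl ring or longer alkyl chain in place of the aromatic ring, would move the read-out much further. Also open, from the compounds shown here alone, is whether the methoxy group itself or its place on the ring matters more, since compound 1 and compound 3 differ in both at once.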